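Compound 1 and its untested benzimidazole analogue

The source may report more compounds than this note shows. Statements on the series, on what has been measured and on what is new or still open speak of the compounds shown alone.

Values so far in a functional assay on K562 cells (Homo sapiens) for inhibition, read by trypan blue exclusion, with a stated time of 72 h (on this read-out higher numbers stand for weaker inhibition and lower numbers for stronger inhibition), are:
- compound 1 `Cn1c(=O)c(S(=O)(=O)c2ccc(F)cc2)cc2cnc(Nc3ccc4cc[nH]c4c3)nc21` gives 10000 nM
- compound 2 `Cc1ccc(S(=O)(=O)c2cc3cnc(Nc4ccc5cc[nH]c5c4)nc3n(C)c2=O)cc1` gives 15000 nM
- compound 3 `Cn1c(=O)c(S(=O)(=O)c2ccc(F)cc2F)cc2cnc(Nc3ccc4cc[nH]c4c3)nc21` gives 5000 nM

Compound 1 stands in the middle of these three numbers, and neither of its measured steps leaves the scatter: a 1.5-fold higher number from compound 1 to compound 2 (0.18 log units; within the scatter) and a 2.0-fold lower number from compound 1 to compound 3 (0.30 log units; within the scatter) are the two in question. Only a 3.0-fold lower number from compound 2 to compound 3 (0.48 log units; beyond the scatter) goes beyond it, and that step is modest.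

The next compound to be measured is compound 4 `Cn1c(=O)c(S(=O)(=O)c2ccc(F)cc2)cc2cnc(Nc3ccc4[nH]cnc4c3)nc21` with the change 1H-benzimidazol-5-yl in place of 1H-indol-6-yl on a nitrogen on an aromatic ring on the core of compound 1, that is, 1H-benzimidazol-5-yl in place of 1H-indol-6-yl on a nitrogen on an aromatic ring. Going by the values given here, none of the measured steps touches this group. All three concern the group on the sulfonyl sulfur, so they bear on the new change only as a rough gauge of how far this small set moves. The data give no direction for the exchange, so no step beyond the scatter can be expected with any confidence. The expected outcome is a 1.1-fold lower number from compound 1 to compound 4 (0.05 log units; within the scatter) in this assay as the central reading. Compound 4 is estimated at 9000 nM (expected range 3000 nM to 27000 nM).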

Compound 4, half-maximal inhibitory concentration: 10000 nM
Beside the measured number, compound 4's estimate is 1.1-fold (0.05 log units) below it; the measured number falls inside the stated range.
By their numbers in this assay, from the lowest: compounds 3, 1, 4 and 2 (each within the scatter of the next, the first and the last beyond it).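

Going by these compounds alone, the exchange of 1H-indol-6-yl for 1H-benzimidazol-5-yl on the nitrogen gives no change at the digits printed from compound 1 to compound 4 (within the scatter) in this assay, and this is the first measured step at this group, since the earlier steps all concerned the group on the sulfonyl sulfur. The entering group has a ring nitrogen and a hydrogen-bond acceptor that the leaving group lacks, and it also has a different point of attachment, yet with the 4-fluorophenyl sulfonyl group held constant, this read-out registers no difference between the two. Nothing measured here gives a reason for this flat result.

A single exchange cannot show whether this place is generally insensitive to change, or whether the same exchange would also leave the number unmoved with the 2,4-difluorophenyl group of compound 3 on the sulfonyl sulfur. The compounds shown also leave open what would happen if the bicyclic group on the nitrogen gave way to a phenyl ring carrying a morpholine or a carboxylic acid, which would alter this part of the molecule far more than the exchange of one ring atom does.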